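Thiophene in place of pyrrole on the thiosemicarbazone arm

The source may hold more compounds than are shown below. What is called first, only, known or untested is meant among the compounds shown, and "the series" means these compounds.

Compound 1 `CC1=CC[C@H](C(C)(C)NC(=S)N/N=C/c2ccco2)CC1`: 13800 nM
Compound 2 `CC1=CC[C@H](C(C)(C)NC(=S)N/N=C/c2ccc[nH]2)CC1`: > 100000 nM

Two compounds share one core and differ only in the five-membered ring joined to the carbon with a double bond to nitrogen. In a functional assay on OVCAR-3 cells (Homo sapiens) for inhibition, read by sulforhodamine B assay, with a stated time of 48 h (on this read-out lower numbers stand for stronger inhibition of growth and higher numbers for weaker inhibition of growth), compound 1, bearing furan-2-yl, gives 13800 nM. Compound 2, bearing 1H-pyrrol-2-yl, reaches only the limit of > 100000 nM, so for it no number is known; it sits at the limit of > 100000 nM in this assay, at which 1 of the 2 values shown sits. The step of an at least 7.2-fold higher number from compound 1 to compound 2 (0.86 log units; beyond the scatter) is therefore only a lower bound on how far the pyrrole compound falls behind the furan compound.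

Compound 3 `CC1=CC[C@H](C(C)(C)NC(=S)N/N=C/c2cccs2)CC1` is not yet measured. It differs from compound 2 by thiophen-2-yl in place of 1H-pyrrol-2-yl on a carbon with a double bond to nitrogen. Within the data shown here, the only step that bears on this change is an at least 7.2-fold higher number from compound 1 to compound 2 (0.86 log units; beyond the scatter), which shows that swapping one five-membered heteroaryl for another can move the number beyond the scatter. Because compound 1 with furan-2-yl gives 13800 nM, compound 3 is expected to come back into the measurable range, an expected step of an at least 6.6-fold lower number from compound 2 to compound 3 (0.82 log units; beyond the scatter). The estimate for compound 3 is 15000 nM, within 5000 nM to 60000 nM.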

Compound 3, concentration for total growth inhibition: 35100 nM
Compound 3: middle estimate off by 2.3-fold (0.37 log units), on the low side; measured number inside the range.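

The thiophene result shows that the loss seen with the pyrrole is not shared by every five-membered heteroaryl at this place: in this assay, the change gives an at least 2.8-fold lower number from compound 2 to compound 3 (0.45 log units; beyond the scatter), and thiophen-2-yl returns a measurable number. Compound 2 remains a limit and not a number, so this step is only a lower bound: the limit of > 100000 nM in this assay, at which 1 of the 3 values shown sits.

The comparison with furan-2-yl adds a second finding, as a 2.5-fold higher number from compound 1 to compound 3 (0.41 log units; beyond the scatter) shows that even the two heteroaryls with measurable numbers are separated beyond the scatter, giving the order furan-2-yl, thiophen-2-yl, 1H-pyrrol-2-yl from lower to higher numbers among these compounds.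

Going by these compounds, what remains open is whether the hydrogen-bond donor of 1H-pyrrol-2-yl, which thiophen-2-yl lacks, has any part in the step, and a pyrrole with a methyl group on its nitrogen would bear on that question. The compounds shown also leave open how a six-membered ring such as phenyl or pyridine would read on a carbon with a double bond to nitrogen.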